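The compounds below may be only part of what the source reports. "The series", "measured", "known", "first", "only" and "open" are said of these compounds alone.

Measured compounds:
compound 1 `O=C(Nc1cccc(-n2cc(-c3ccncc3)c(-c3ccc(Cl)c(O)c3)n2)c1)Nc1ccc(Cl)c(Cl)c1` — > 32500 nM
compound 2 `COc1cc(-c2nn(-c3cccc(NC(=O)c4cccc(C(F)(F)F)c4)c3)cc2-c2ccncc2)ccc1Cl` — > 50000 nM
compound 3 `COc1cc(-c2nn(-c3cccc(NC(=O)Nc4cccc(C(F)(F)F)c4)c3)cc2-c2ccncc2)ccc1Cl` — > 50000 nM

All three were tested in a functional assay on MOLT-4 cells (Homo sapiens) for inhibition, read by sulforhodamine B assay, with a stated time of 48 h; on this read-out lower numbers stand for higher toxicity in this test and higher numbers for lower toxicity in this test. None of the three returned a number. Compound 1 stands at a limit of this assay, (the limit of > 32500 nM in this assay, at which 1 of the 3 values shown sits). Compound 2 and compound 3 stand at another limit of this assay, (the limit of > 50000 nM in this assay, at which 2 of the 3 values shown sit). For the measured compounds named here, the only measured step between structures that differ in one place is a step that the two limits leave unreadable from compound 2 to compound 3, and since both ends are limits its size cannot be read.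

Compound 4 `O=C(Nc1cccc(-n2cc(-c3ccncc3)c(-c3ccc(Cl)c(O)c3)n2)c1)Nc1ccc(Cl)c(C(F)(F)F)c1` is the next structure. It differs from compound 1 in one place: trifluoromethyl in place of chloro on an aromatic carbon. Read one bond further out, the 3,4-dichlorophenyl group of compound 1 becomes a 4-chloro-3-(trifluoromethyl)phenyl group in compound 4.

Going by the values given here, no measured step bears on this exchange, and the one step that was measured, a step that the two limits leave unreadable from compound 2 to compound 3, is itself unreadable. What is expected for compound 4 therefore rests on compound 1 alone, which sits at a limit, so no step beyond the scatter is expected in either direction. Compound 4 is expected to give about 40000 nM in this assay, in a range from 12000 nM to 120000 nM, which means an expected step that the limit leaves unreadable from compound 1 to compound 4, most likely reported again only as a limit.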

Compound 4, concentration lethal to 50% of the cells: > 32500 nM
Compound 4: a limit, no number; the forecaster's own chance of this, stated with the estimate: 80%; the middle value lies beyond the limit too.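

In this assay compound 4 gives > 32500 nM, which is a limit and not a number. Compound 1 stands at the same limit, so no step between compound 1 and compound 4 can be read: the limit of > 32500 nM in this assay, at which 2 of the 4 values shown sit.

The compounds shown leave open whether the exchange of chloro for trifluoromethyl changes the result in this assay at all, since none of them returns a number there.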